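The source may report more compounds than this note shows. Statements on the series, on what has been measured and on what is new or still open speak of the compounds shown alone.

Compound 3 `COc1ccc(C(=O)/C(=C/c2ccc(Cl)cc2Cl)CC(C)OC(C)=O)cc1` gives 36800 nM in a functional assay on NB-4 cells (Homo sapiens) for inhibition, read by XTT assay, with a stated time of 48 h (on this read-out lower numbers stand for stronger inhibition and higher numbers for weaker inhibition), standing at the upper end of the three numbers recorded. Compound 1 `COc1ccc(C(=O)/C(=C/C2CCCCC2)COC(C)=O)cc1` gives 23300 nM, which lies within the scatter of compound 3, while compound 2 `COc1ccc(C(=O)/C(=C/C2CCCCC2)COC(=O)c2ccccc2)cc1` gives 10200 nM, a reading that compound 3 exceeds beyond the scatter. Among the measured compounds shown here, the single measured step, a 2.3-fold lower number from compound 1 to compound 2 (0.36 log units; beyond the scatter), concerns the ester carbonyl and does not touch the position altered here. Compound 4 `COc1ccc(C(=O)/C(=C/C2CCCCC2)CC(C)OC(C)=O)cc1` differs from compound 3 by cyclohexyl in place of 2,4-dichlorophenyl on a double-bonded chain carbon bound to a double-bonded chain carbon, an aromatic ring giving way to a non-aromatic one. For the measured compounds named here, no measured pair isolates this change, and the values of compound 1 and compound 3 suggest both variants sit in one range, so no step beyond the scatter is expected. Compound 4 is therefore expected to give 28000 nM (range 9000 nM to 90000 nM), an expected step of a 1.3-fold lower number from compound 3 to compound 4 (0.12 log units; within the scatter).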

Compound 4, half-maximal inhibitory concentration: 33400 nM
Estimate against measurement, compound 4: 1.2-fold (0.08 log units) below, within the range that was stated.
By their numbers in this assay, from the lowest: compound 2; then compounds 1, 4 and 3 (each within the scatter of the next).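

In this assay the step from aromatic 2,4-dichlorophenyl to non-aromatic cyclohexyl on a double-bonded chain carbon bound to a double-bonded chain carbon is a 1.1-fold lower number from compound 3 to compound 4 (0.04 log units; within the scatter) and so, on this pair, losing the aromatic ring and both chlorine atoms leaves no change that can be told from scatter. Among the compounds shown here, on a saturated chain carbon bound to a double-bonded chain carbon, 1-acetoxyethyl in place of acetoxy gives a 1.4-fold higher number from compound 1 to compound 4 (0.16 log units; within the scatter) and also stays inside the scatter, while 1-acetoxyethyl in place of benzoyloxy gives a 3.3-fold higher number from compound 2 to compound 4 (0.52 log units; beyond the scatter) and is the only one of these three steps that goes beyond it. Nothing at hand explains these readings. Going by these compounds, whether an amine or a carboxylic acid on the ring would move the number remains open, as does whether benzoyloxy would keep its lower number alongside 2,4-dichlorophenyl.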